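Amide-side aryl swap from compound 2 to compound 4

This account rests on a few compounds, and the source may have more. Where it says the series, first, only, none or still open, it means among the compounds named here.

Compound 1 `C[C@@H](Nc1c(C(=O)NCc2ccc(F)cc2)nc(Br)c2cccnc12)c1ccccc1`: > 20000 nM
Compound 2 `N[C@H]1CC[C@H](Nc2c(C(=O)NCc3ccccn3)nc(Br)c3cccnc23)CC1`: "not determined" (no result reported)
Compound 3 `COC(=O)CNc1c(C(=O)NCc2ccc(F)cc2)nc(Br)c2cccnc12`: > 10000 nM

In a functional assay on HCT-116 cells (Homo sapiens) for cytotoxicity, read by MTT assay, with a stated time of 72 h (on this read-out higher numbers stand for weaker inhibition and lower numbers for stronger inhibition), compound 1 reaches only a limit of the assay, > 20000 nM. In this assay compound 3 likewise sits at a limit, > 10000 nM. Compound 2 has no result in this assay, its entry reading "not determined" (no result reported), so it stands nowhere on the numbers shown. Within the data shown here, the single measured step, a step that the two limits leave unreadable from compound 1 to compound 3, runs between two limits, the limit of > 20000 nM in this assay, at which 1 of the 3 values shown sits, and (the limit of > 10000 nM in this assay, at which 1 of the 3 values shown sits), and its size cannot be read. Compound 4 `COc1ccc(CNC(=O)c2nc(Br)c3cccnc3c2N[C@H]2CC[C@H](N)CC2)cc1` differs from compound 2 by 4-methoxyphenyl in place of pyridin-2-yl on a saturated chain carbon bound to an amide-type nitrogen. Among the measured compounds shown here, no measured step bears on this change. For compound 4 the estimate in this assay is 15000 nM, expected between 3000 nM and 60000 nM, with a limit rather than a number quite possible.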

Compound 4, half-maximal inhibitory concentration: 3000 nM
Beside the measured number, compound 4's estimate is 5.0-fold (0.70 log units) above it; the range from low to high includes it.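

Compound 2 carries no number and compound 4 gives 3000 nM, so no step can be read between them. The compounds shown leave open what 4-methoxyphenyl in place of pyridin-2-yl does to the read-out.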